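Methylamino in Place of Chloro: What to Expect

The source may report more compounds than this note shows. Statements on the series, on what has been measured and on what is new or still open speak of the compounds shown alone.

Measured compounds:
compound 1, `CCCCCCNC(=O)n1cc(C)c(=O)[nH]c1=O`: 1460 nM
compound 2, `CCCCCCNC(=O)n1cc(Cl)c(=O)[nH]c1=O`: 67 nM
compound 3, `CCCCCCNC(=O)n1cc(C#N)c(=O)[nH]c1=O`: no number reported
compound 4, `CCCCCCNC(=O)n1cc(NC)c(=O)[nH]c1=O`: not yet measured

All four share one core and differ only in a single group on an aromatic carbon. In an assay on HEK293 cells for inhibition of acid ceramidase (Rattus norvegicus), read by LC-MS, with a stated time of 30 min (a lower number here means a stronger inhibitor, a higher number a weaker inhibitor), compound 1 gives 1460 nM, and compound 2 gives 67 nM. In this assay compound 3 gives no result reported. Among the two numbers available, compound 2 has the lowest, and the only measured step, a 22-fold lower number from compound 1 to compound 2 (1.34 log units; beyond the scatter), is large and lies beyond the scatter.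

The change from compound 2 to compound 4 is methylamino in place of chloro on an aromatic carbon. Among the measured compounds shown here, no measured step involves methylamino, so the one step available bears on it only indirectly: it shows that the group at this position can move the number in this assay by a large amount, and that chloro gives the lower number of the two groups tried. With methylamino being a third, untested group, the expectation is that compound 4 returns toward the number of compound 1 rather than improving on compound 2, so a rise is expected, a 30-fold higher number from compound 2 to compound 4 (1.47 log units; beyond the scatter). Compound 4 is estimated at 2000 nM, within a wide range from 300 nM to 12000 nM.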

Compound 4, half-maximal inhibitory concentration: 3400 nM
For compound 4 the middle estimate is 1.7-fold (0.23 log units) below the measured one, within the range that was stated.
By their numbers in this assay, from the lowest: compound 2; then compound 1; then compound 4.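

In this assay, methylamino in place of chloro gives a 51-fold higher number from compound 2 to compound 4 (1.71 log units; beyond the scatter), a large loss that makes compound 4 the weakest of the three compounds with a number. Methylamino in place of methyl gives a 2.3-fold higher number from compound 1 to compound 4 (0.37 log units; beyond the scatter), a modest step but one beyond the scatter, so the order at this position among the groups with numbers runs from chloro through methyl to methylamino, and a group with a nitrogen attached to the aromatic carbon does not restore what chloro gives. The change adds a hydrogen-bond donor and a hydrogen-bond acceptor that chloro lacks, but nothing available here tells which feature of methylamino accounts for the rise.

As far as these compounds go, the steps to compound 3 cannot be read, so the place of the nitrile group in this order remains unknown. Also open, from the compounds shown here alone, is whether bromo or methoxy at this position would fall nearer to chloro or to methylamino, and whether a plain amino group or a dimethylamino group would differ from methylamino.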